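Lengthening a Saturated Chain on a Shared Core

A few compounds are considered here, and "the series" means these few. Any claim that something is new, unique, unknown or untested is made for them only; others in the source may bear on it.

Compound 1 `CCCCCc1cc2c(=O)n(CCCSc3nc(-c4cc(OC)c(OC)c(OC)c4)c(C#N)c(=O)[nH]3)cnc2s1`, compound 2 `CCCCCCc1cc2c(=O)n(CCSc3nc(-c4cc(OC)c(OC)c(OC)c4)c(C#N)c(=O)[nH]3)cnc2s1` and compound 3 `CCCCCCc1cc2c(=O)n(CCCSc3nc(-c4cc(OC)c(OC)c(OC)c4)c(C#N)c(=O)[nH]3)cnc2s1` are built on one core and differ only in the saturated chain that hangs from an aromatic carbon and in the short chain that joins the two parts of the molecule. In an ADME assay on THP-1 cells (Homo sapiens) for inhibition, read by MTT assay (a higher number here means a weaker inhibitor of growth, a lower number a stronger inhibitor of growth), compound 1 reaches only the limit of the assay, > 100 ug/mL. Compound 2 gives 96.4 ug/mL in this assay. Compound 3 gives 54.3 ug/mL in this assay, and this number and that of compound 2 lie within the usual scatter of each other, so neither can be called the stronger inhibitor of growth. Compound 1 alone sits at the assay's limit: the limit of > 100 ug/mL in this assay, at which 1 of the 3 values shown sits.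

Compound 4 `CCCCCCCc1cc2c(=O)n(CCCSc3nc(-c4cc(OC)c(OC)c(OC)c4)c(C#N)c(=O)[nH]3)cnc2s1` is not yet measured. Relative to compound 3 it carries methyl in place of hydrogen on a saturated chain carbon, six bonds along the chain from an aromatic carbon. Going by the values given here, one measured step speaks to such a change, the one from compound 1 to compound 3, also a methyl added to the same chain: an at least 1.8-fold lower number from compound 1 to compound 3 (0.26 log units; that floor lies within the scatter). That step points downward, but only at a floor that the scatter could cover, so in this assay a small move downward or no move beyond the scatter is the reasonable expectation. Compound 4 is therefore expected to give about 40 ug/mL in this assay, between 20 ug/mL and 85 ug/mL, an estimated step of a 1.4-fold lower number from compound 3 to compound 4 (0.13 log units; within the scatter) from compound 3.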

Compound 4, concentration for 50% growth inhibition: 68.2 ug/mL
Compound 4: middle estimate off by 1.7-fold (0.23 log units), on the low side; measured number inside the range.
By their numbers in this assay, from the lowest: compounds 3, 4 and 2 (each within the scatter of the next). At a limit, above all of these: compound 1.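

Going by these compounds alone, compound 3 and compound 4 are the first pair on this chain for which both numbers are real measurements, so this step has a definite size rather than a floor. With a methyl in place of hydrogen on a saturated chain carbon, six bonds along the chain from an aromatic carbon, this assay gives a 1.3-fold higher number from compound 3 to compound 4 (0.10 log units; within the scatter), so this one-carbon extension produces no change that can be told from repeat-measurement noise. The wider ethyl difference gives an at least 1.4-fold lower number from compound 1 to compound 4 (0.16 log units; that floor lies within the scatter), and it can be read only as a floor because compound 1 stands at a limit rather than at a number: the limit of > 100 ug/mL in this assay, at which 1 of the 4 values shown sits.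

The compounds shown leave open whether a longer chain at this place would bring a change beyond the scatter, or whether the growth-inhibition number would continue to stay within it. They also leave open what a chain ending in an amine or a carboxylic acid would do here, since every chain end shown is a plain saturated carbon.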